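The source may hold more compounds than are shown below. What is called first, only, known or untested is meant among the compounds shown, and "the series" means these compounds.

Compound 2 `O=C(Nc1cccc(/C=C/C(=O)c2nc3ccccc3[nH]2)c1)c1ccc(Br)cc1` stands with the lowest number of the two measured in a functional assay on HCT-116 cells (Homo sapiens) for antiproliferative activity, read by MTT assay, with a stated time of 48 h (a lower number here means a stronger inhibitor, a higher number a weaker inhibitor), giving 2230 nM; compound 1 `O=C(Nc1cccc(/C=C/C(=O)c2nc3ccccc3[nH]2)c1)c1ccc(Cl)cc1` gives 2270 nM, and the step of a 1.0-fold lower number from compound 1 to compound 2 (0.01 log units; within the scatter) lies within the scatter. Compound 3 `Cc1ccccc1C(=O)Nc1cccc(/C=C/C(=O)c2nc3ccccc3[nH]2)c1` carries 2-methylphenyl in place of 4-bromophenyl on a carbonyl carbon. Going by the values given here, no measured step touches that position in the same way; only the halogen swap from compound 1 to compound 2, which moved the number hardly at all, bears on the amide-side aryl, so for compound 3 the number in this assay is expected to stay close to that of compound 2, a step of a 1.3-fold higher number from compound 2 to compound 3 (0.13 log units; within the scatter) at most. The estimate for compound 3 is 3000 nM, with a range of 1000 nM to 9000 nM.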

Compound 3, half-maximal inhibitory concentration: 1870 nM
Compound 3: the middle estimate sits 1.6-fold (0.21 log units) above what was measured; the measured number falls inside the stated range.
By their numbers in this assay, from the lowest: compounds 3, 2 and 1 (each within the scatter of the next).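

In this assay, the change on the carbonyl carbon now goes beyond a halogen swap: 2-methylphenyl in place of 4-bromophenyl gives (a 1.2-fold lower number from compound 2 to compound 3 (0.08 log units; within the scatter)), and 2-methylphenyl in place of 4-chlorophenyl gives (a 1.2-fold lower number from compound 1 to compound 3 (0.08 log units; within the scatter)). The three aryl groups therefore read level, so replacing the halogen with a methyl group and changing its printed ring position leaves the number within the scatter here. Nothing at hand accounts for this flat reading.

On these data alone, it remains open whether an amine or a carboxylic acid on this ring, or a longer alkyl chain in place of the ring, would move the number beyond the scatter.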